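Methoxy for dimethylamino on the core of compound 1

This account rests on a few compounds, and the source may have more. Where it says the series, first, only, none or still open, it means among the compounds named here.

Measured so far in a functional assay on HeLa S3 cells (Homo sapiens) for antiproliferative activity, read by XTT assay, with a stated time of 72 h; on this read-out higher numbers stand for weaker inhibition and lower numbers for stronger inhibition:
compound 1 `CN(C)c1ncnc2c1c(-c1cc3ccccc3o1)cn2[C@@H]1O[C@H](CO)[C@@H](O)[C@H]1O` — > 20000 nM
compound 2 `C#Cc1cn([C@@H]2O[C@H](CO)[C@@H](O)[C@H]2O)c2ncnc(N(C)C)c12` — 810 nM
compound 3 `CNc1ncnc2c1c(-c1cccs1)cn2[C@@H]1O[C@H](CO)[C@@H](O)[C@H]1O` — > 20000 nM

Compound 1 sits at a limit of this assay, > 20000 nM, so no number is known for it. Compound 3 likewise gives only a limit, > 20000 nM. Compound 2 gives a numerical value, 810 nM. For the measured compounds named here, the one measured step, an at least 24-fold lower number from compound 1 to compound 2 (1.39 log units; beyond the scatter), concerns a different place on the core and does not bear on the change now at hand.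

Compound 4 `COc1ncnc2c1c(-c1cc3ccccc3o1)cn2[C@@H]1O[C@H](CO)[C@@H](O)[C@H]1O` differs from compound 1 by methoxy in place of dimethylamino on an aromatic carbon. Going by the values given here, no measured pair shows this exchange, so its effect in this assay is unknown. What is known is the limit of > 20000 nM in this assay, at which 2 of the 3 values shown sit, and compound 1 is one of those two. With compound 1 already at the limit, a change that left the number unchanged or made it larger would again yield only a limit; only a large drop would give a number.

The expectation for compound 4 is therefore 30000 nM, within 8000 nM to 100000 nM, most likely reported again as a limit. The step this estimate implies is a step that the limit leaves unreadable from compound 1 to compound 4, not expected to lie beyond the scatter.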

Compound 4, half-maximal inhibitory concentration: 9240 nM
Beside the measured number, compound 4's estimate is 3.2-fold (0.51 log units) above it, and the stated range covers the measured number.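

In this assay, the place on the core that carries dimethylamino proves responsive with 1-benzofuran-2-yl kept on the core: methoxy in place of dimethylamino gives an at least 2.1-fold lower number from compound 1 to compound 4 (0.33 log units; beyond the scatter). Compound 1 gives only a limit, > 20000 nM, so this step is a lower bound on the change and its full size cannot be read. Among the compounds shown, ethynyl is no longer the only group that comes with a measured number, since compound 4 gives one while keeping 1-benzofuran-2-yl.

On these data alone, whether methoxy would act in the same way with ethynyl on the core remains open. Also open, as far as these compounds go, is what a primary amine or a longer alkoxy chain such as ethoxy would give on this aromatic carbon.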